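A few compounds are considered here, and "the series" means these few. Any claim that something is new, unique, unknown or untested is made for them only; others in the source may bear on it.

Measured so far:
- compound 1 `CCC(C(=O)N1CCN(c2ccccc2F)CC1)N1C(=O)CCC1=O`: 0% in a functional assay on the whole organism (strain Swiss) with Mus musculus as the target, in the maximal electroshock model, with a stated time of 1 h, at a dose of 100 mg/kg by the intraperitoneal route; on this read-out higher numbers stand for a stronger effect at the one dose given and lower numbers for a weaker effect
- compound 2 `COc1cccc(N2CCN(C(=O)C(C)N3C(=O)CCC3=O)CC2)c1`: 0% in this assay
- compound 3 `CCC(C(=O)N1CCN(c2ccccc2)CC1)N1C(=O)CCC1=O`: 0% in this assay

Compound 3 stands level with both compounds 1 and 2; none of the three gives any detectable effect at the dose used. Among the compounds with values here, the only measured step that changes a single place is the one on the aromatic ring: no change at the digits printed from compound 1 to compound 3 (within the scatter), which is within the scatter. Compound 2, which carries a different group on its aromatic ring and a different chain beside the amide, sits at the same level, so across these three compounds nothing that was varied on the ring has moved the read-out at all.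

The new compound, compound 4 `CCC(C(=O)N1CCN(c2cccc(C(F)(F)F)c2)CC1)N1C(=O)CCC1=O`, differs from compound 3 in one place: trifluoromethyl in place of hydrogen on an aromatic carbon. Within the data shown here, no measured step involves a trifluoromethyl group, so the expectation rests on the general picture that substitution on this ring, whether fluoro or hydrogen or methoxy, has left the read-out unchanged. The step expected in this assay is therefore none beyond the scatter: no change at the digits printed from compound 3 to compound 4 (within the scatter). For compound 4 the estimated value is 0%, with a range from 0% to 10%.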

Compound 4, a percentage reported as activity, at one dose (the size of the read-out at that dose, not a potency): 0%
Beside the measured number, compound 4's estimate shows no gap at the digits printed; measured number inside the range.
By their numbers in this assay, from the lowest: compounds 1, 2, 3 and 4 (each within the scatter of the next).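

In this assay, the step of no change at the digits printed from compound 3 to compound 4 (within the scatter) brings in trifluoromethyl, a group of 4 heavy atoms, where the earlier step on the ring exchanged only hydrogen and fluoro. It shows that this much larger group, placed on an aromatic carbon meta to a large group, still does not raise the read-out: compound 4 gives 0%, the same printed value as compound 3. That level also limits what the step can say, as a compound with no measurable effect has nothing left to lose, so the result shows only that no activity appeared, not whether trifluoromethyl would weaken an active compound. No available measurement bears on why the read-out stays at this level.

The compounds shown leave open whether an amine or a carboxylic acid on this aromatic carbon would produce any effect in this assay. They also leave open whether a longer chain in place of the one on the shared core would give a measurable read-out, against which ring changes could then be compared.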